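Swapping fluoro for hydrogen on a growth-inactive compound

The source may hold more compounds than are shown below. What is called first, only, known or untested is meant among the compounds shown, and "the series" means these compounds.

Values from a functional assay on U-251 cells (Homo sapiens) for inhibition, read by sulforhodamine B assay, with a stated time of 48 h; on this read-out higher numbers stand for weaker inhibition of growth and lower numbers for stronger inhibition of growth
- Compound 1 (`CCOC(=O)c1nn(-c2ccccc2)c(-c2ccc(F)cc2)c1CNC(C)(C)C`) gives > 632000 nM; > 579000 nM (2 entries) (limits)
- Compound 2 (`CC(C)(C)NCc1c(C(=O)O)nn(-c2ccccc2)c1-c1ccc(F)cc1`) gives > 680000 nM (a limit)

Compound 2 has no exact number on this read-out, only a limit (> 680000 nM). The same holds for compound 1, which also gave only limits (> 632000 nM; > 579000 nM (2 entries)).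

Compound 3 (`CC(C)(C)NCc1c(C(=O)O)nn(-c2ccccc2)c1-c1ccccc1`) differs from compound 2 at a single place (hydrogen in place of fluoro on an aromatic carbon). Hydrogen stands in place of fluoro on an aromatic carbon, so 4-fluorophenyl becomes phenyl. Among the measured compounds shown here, no measured pair shows what this swap does in this assay, so no change beyond the usual scatter is expected. The expected step (a step that the limit leaves unreadable from compound 2 to compound 3) is therefore small, and it rests on the limit of compound 2 (> 680000 nM). The estimated value for compound 3 is 700000 nM (expected range 350000 nM to 1000000 nM).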

Compound 3, concentration for 50% growth inhibition: > 716000 nM
Compound 3: only a limit was reported (the forecaster's own chance of this, stated with the estimate: 85%); middle value at least 1.0-fold (0.00 log units) from the limit.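

In this assay compound 3 gives > 716000 nM, which is a limit and not a number. Among the compounds shown here, compound 2 also gave only a limit, so no step between compound 2 and compound 3 can be read. The compounds shown leave open whether 4-fluorophenyl and phenyl differ at all in their effect on growth.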